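Fluoro on the amide-side ring: working notes

The compounds below may be only part of what the source reports. "The series", "measured", "known", "first", "only" and "open" are said of these compounds alone.

Measured so far:
compound 1 `O=C(C1CCC1)N1CCc2nc(C#Cc3ccccc3)sc2C1`: 370 nM
compound 2 `O=C(C1CC(F)C1)N1CCc2nc(C#Cc3ccccc3)sc2C1`: > 10000 nM
compound 3 `O=C(N1CCCCC1)N1CCc2nc(C#Cc3ccccc3)sc2C1`: > 10000 nM

In an assay on HEK293 cells for negative allosteric modulation of metabotropic glutamate receptor 5 (Homo sapiens), read by FLIPR, with a stated time of 1 h (a higher number here means a weaker inhibitor, a lower number a stronger inhibitor), compound 1 gives 370 nM. For compound 2 the value > 10000 nM is a limit of the assay, not a number. For compound 3 the value > 10000 nM is likewise a limit. The change fluoro in place of hydrogen on a saturated ring carbon produced an at least 27-fold higher number from compound 1 to compound 2 (1.43 log units; beyond the scatter). The two cores differ by piperidin-1-yl in place of cyclobutyl on a carbonyl carbon, and this produced an at least 27-fold higher number from compound 1 to compound 3 (1.43 log units; beyond the scatter). Between compounds 2 and 3 the step is a step that the two limits leave unreadable from compound 2 to compound 3, both sitting at the limit of > 10000 nM in this assay, at which 2 of the 3 values shown sit.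

Compound 4 `O=C(N1CCC(F)CC1)N1CCc2nc(C#Cc3ccccc3)sc2C1` is not yet measured. It differs from compound 3 by fluoro in place of hydrogen on a saturated ring carbon. This is the same kind of change as from compound 1 to compound 2, but the place differs: there, a four-membered non-aromatic ring of carbon only, two ring bonds from the ring atom that bears a large group; here, a six-membered non-aromatic ring with 1 nitrogen, three ring bonds from the ring nitrogen. In this assay the expected step is a step that the limit leaves unreadable from compound 3 to compound 4, resting on compound 3 standing at the limit of > 10000 nM in this assay, at which 2 of the 3 values shown sit, and on the matching change giving an at least 27-fold higher number from compound 1 to compound 2 (1.43 log units; beyond the scatter). Compound 4 is estimated at 30000 nM, between 10000 nM and 100000 nM, most likely reported only as a limit.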

Compound 4, half-maximal inhibitory concentration: > 10000 nM
Compound 4 ended at the assay's limit; the forecaster's own chance of this, stated with the estimate: 85%; the middle value is on the limit's open side.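

In this assay compound 4 gives > 10000 nM, which is a limit of the assay and not a number. The steps from compound 3 to compound 4 and from compound 2 to compound 4 cannot be read, so the fluoro change is neither confirmed nor contradicted on the piperidin-1-yl compounds, and the reason is that these values rest on the same limit: the limit of > 10000 nM in this assay, at which 3 of the 4 values shown sit.
Among the compounds shown here, the one readable step is an at least 27-fold higher number from compound 1 to compound 4 (1.43 log units; beyond the scatter), for 4-fluoropiperidin-1-yl in place of cyclobutyl on a carbonyl carbon, and it says nothing about fluoro taken alone.

Open, going by these compounds, is whether fluoro in place of hydrogen has any readable effect on a ring whose parent compound gives a value short of the limit, as compound 1 alone does here. Also open, on these data alone, is how a hydroxyl in place of fluoro, or a cyclopentyl or a longer alkyl chain on the carbonyl carbon, would read in this assay.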